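A few compounds are considered here, and "the series" means these few. Any claim that something is new, unique, unknown or untested is made for them only; others in the source may bear on it.

Working notes on the series. Compound 1 (`O=C1c2ccc(OCc3cccc(-c4ccc(Cl)cc4F)c3)cc2CN1C1CCCC1`) has no number to start from: in an ADME assay on a cell-free system (plasma, Rattus norvegicus) for metabolic stability, read by LC-MS, with a stated time of 1 h, at 37 degrees C, tested at 100 uM (a lower number here means that less of the compound is left, a higher number that more of the compound is left), compound 1 gives "not determined" (no result reported) and so gives no baseline. For the measured compounds named here, the only measured reading comes from compound 2 (`O=C(O)c1cc(-c2cccc(COc3ccc4c(=O)n(C5CCCC5)sc4c3)c2)ccc1F`), where compound 2 gives 100% as its result. Compound 3 (`Cc1ccc(C(=O)O)cc1-c1cccc(COc2ccc3c(c2)CN(C2CCCC2)C3=O)c1`) is still to be measured. The change, 5-carboxy-2-methylphenyl in place of 4-chloro-2-fluorophenyl on an aromatic carbon, meta to a large group, is counted as 5-carboxy-2-methylphenyl in place of 4-chloro-2-fluorophenyl on an aromatic carbon in full. With no value for compound 1, the step can be expected only loosely: no loss beyond the usual scatter is expected, and compound 3 is expected to stay near the level of compound 2 at 100% on that single reading. This rests on one compound only. For compound 3 the expected value is 94% within an estimated range of 78% to 100% in this measurement.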

Compound 3, percent of the compound remaining: 100%
Estimate against measurement, compound 3: 6 percentage points below; measured number inside the range.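

Compound 1 offers no number to set against compound 3, so no step can be read between them. The compounds shown leave open what replacing 4-chloro-2-fluorophenyl with 5-carboxy-2-methylphenyl does to the percent of compound remaining. No evidence bears on this result.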